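Swapping the amide substituent on a triaryl pyrrole acetamide

This account rests on a few compounds, and the source may have more. Where it says the series, first, only, none or still open, it means among the compounds named here.

Two compounds have so far been run in an ADME assay on HEK-293T cells (Homo sapiens) for cytotoxicity, read by MTT assay, with a stated time of 72 h, tested at 50 uM; on this read-out lower numbers stand for less inhibition and higher numbers for more inhibition at the one concentration tested (going by the name of the read-out). Compound 1 `CCc1nnc(NC(=O)Cn2c(-c3ccccc3)cc(-c3ccccc3)c2-c2ccco2)s1` gives 81% in this assay. Compound 2 `O=C(Cn1c(-c2ccccc2)cc(-c2ccccc2)c1-c1ccccc1)Nc1nc2ccccc2s1` gives 55% in this assay, the lowest of the two numbers, with compound 1 standing higher by a margin beyond the scatter. Compound 3 `CCc1nnc(NC(=O)Cn2c(-c3ccccc3)cc(-c3ccccc3)c2-c2ccccc2)s1` has not yet been measured. It differs from compound 2 in one place: 5-ethyl-1,3,4-thiadiazol-2-yl in place of 1,3-benzothiazol-2-yl on an amide-type nitrogen. For the measured compounds named here, the entering group is the one carried by compound 1, though compound 1 also differs from compound 3 in the core. Going by the values given here, no step between measured compounds covers this exact change. Since compound 1 carries 5-ethyl-1,3,4-thiadiazol-2-yl and gives 81%, an upward step is expected, of roughly a number 15 percentage points higher from compound 2 to compound 3 (beyond the scatter). Compound 3 is estimated at 70% in this assay, within a range from 50% to 90%.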

Compound 3, a percentage reported as inhibition, at one concentration (the size of the read-out at that concentration, not a potency): 49.3%
Estimate against measurement, compound 3: 20.7 percentage points above; the whole stated range lies above it.
By their numbers in this assay, from the lowest: compounds 3 and 2 (each within the scatter of the next); then compound 1.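

In this assay, 5-ethyl-1,3,4-thiadiazol-2-yl in place of 1,3-benzothiazol-2-yl on the amide-type nitrogen gives a number 5.7 percentage points lower from compound 2 to compound 3 (within the scatter), so these two groups cannot be told apart at this position on the shared core. With 5-ethyl-1,3,4-thiadiazol-2-yl held constant, phenyl in place of furan-2-yl on an aromatic carbon gives a number 31.7 percentage points lower from compound 1 to compound 3 (beyond the scatter), so in this pair the gap belongs to the furan-2-yl to phenyl change and does not follow from the amide substituent. Nothing on hand explains either step.

On these data alone, whether furan-2-yl would carry the same difference with 1,3-benzothiazol-2-yl on the amide remains open. Also open, as far as these compounds go, is how a thiophene ring on that aromatic carbon, or a methyl in place of the ethyl, would read.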